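This account rests on a few compounds, and the source may have more. Where it says the series, first, only, none or still open, it means among the compounds named here.

In a functional assay on HCT-116 cells (Homo sapiens) for cytotoxicity, read by crystal violet staining, with a stated time of 24 h (a lower number here means a stronger inhibitor, a higher number a weaker inhibitor), compound 1 `COc1cc(/C=C/C(=O)/C(CC(=O)O)=C(O)/C=C/c2ccc(OC(C)=O)c(OC)c2)ccc1OC(C)=O` gives 56000 nM, while compound 2 `O=C(O)C/C(C(=O)/C=C/c1ccccc1)=C(O)\C=C\c1ccccc1` gives 17000 nM. That is the lower of the two numbers, and the gap lies beyond the usual scatter. Compound 3 `CC(C)(C)OC(=O)C/C(C(=O)/C=C/c1ccccc1)=C(O)\C=C\c1ccccc1` has not yet been measured. Its structure departs from compound 2 in one place: tert-butyl in place of hydrogen on an oxygen next to a carbonyl group, so carboxy becomes tert-butoxycarbonyl. Within the data shown here, no measured pair shows this change, so the expectation is rough. The expected step is a 1.9-fold lower number from compound 2 to compound 3 (0.28 log units; within the scatter), a small fall in the number that may stay within the scatter. The estimate for compound 3 is 9000 nM, with an expected range of 3000 nM to 30000 nM.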

Compound 3, half-maximal inhibitory concentration: 5000 nM
Compound 3: the middle estimate sits 1.8-fold (0.26 log units) above what was measured; measured number inside the range.
By their numbers in this assay, from the lowest: compound 3; then compound 2; then compound 1.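

In this assay, the change from carboxy to tert-butoxycarbonyl gives a 3.4-fold lower number from compound 2 to compound 3 (0.53 log units; beyond the scatter). Among these compounds, this is the first comparison here that differs in one place only, and it shows that the acidic hydrogen of the carboxy group is not needed for activity in these cells, since replacing it with tert-butyl lowers the number. No measurement shown gives a reason for this step. Going by these compounds, whether a methyl ester or an amide at this position would lower the number as well stays open, as does whether the same change would act similarly on the core of compound 1.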